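The source may report more compounds than this note shows. Statements on the series, on what has been measured and on what is new or still open speak of the compounds shown alone.

In a functional assay on BXPC-3 cells (Homo sapiens) for inhibition, read by MTT assay, with a stated time of 7 days (on this read-out higher numbers stand for weaker inhibition and lower numbers for stronger inhibition), compound 1, `CCCN(CCC)S(=O)(=O)c1ccc(S(=O)(=O)N2CCC[C@@H](C(=O)OCC)C2)cc1`, gives 2500 nM. Compound 2, `CCN1CC(NC(=O)[C@@H]2CCCN(S(=O)(=O)c3ccc(S(=O)(=O)N(CC)CC)cc3)C2)C1`, reaches only a limit of the assay, > 30000 nM; as the limit of > 30000 nM in this assay, at which 1 of the 2 values shown sits, shows, it sits at the edge of what can be measured. Compound 3, `CCN(CC)S(=O)(=O)c1ccc(S(=O)(=O)N2CCC[C@@H](C(=O)NC3CN(S(C)(=O)=O)C3)C2)cc1`, carries methylsulfonyl in place of ethyl on an amine nitrogen in a ring. For the measured compounds named here, no measured pair shows this change, so its size in this assay cannot be read from the numbers, and no step beyond the usual scatter is expected from compound 2 to compound 3. Compound 3 is therefore estimated at 30000 nM, with a range from 8000 nM to 100000 nM, a step of a number no higher from compound 2 to compound 3 (the limit leaves the size open).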

Compound 3, half-maximal inhibitory concentration: 7400 nM
For compound 3 the middle estimate is 4.1-fold (0.61 log units) above the measured one, and the stated range ends above it.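

In this assay, methylsulfonyl in place of ethyl on the amine nitrogen of the four-membered ring gives an at least 4.0-fold lower number from compound 2 to compound 3 (0.60 log units; beyond the scatter), so what sits on this nitrogen clearly matters for the read-out. The true size of the step stays open, because compound 2 stands at a limit and not at a number: the limit of > 30000 nM in this assay, at which 1 of the 3 values shown sits.

An acetyl group or a bare hydrogen on the same nitrogen would help show whether the sulfonyl group itself drives this step. Going by these compounds, whether a longer chain on the sulfonyl sulfur keeps the effect also remains open.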